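The source may hold more compounds than are shown below. What is called first, only, known or untested is meant among the compounds shown, and "the series" means these compounds.

Measured so far in a functional assay on HepG2 cells (Homo sapiens) for cytotoxicity, read by MTT assay, with a stated time of 48 h; on this read-out lower numbers stand for stronger inhibition and higher numbers for weaker inhibition:
- Compound 1 `Cc1ccc(/C=C2/S/C(=N/c3ccccc3)N(Cc3ccncc3)C2=O)cc1` gives 19700 nM
- Compound 2 `CC(C)c1ccc(/C=C2/S/C(=N/c3ccccc3)N(Cc3ccncc3)C2=O)cc1` gives 32300 nM
- Compound 3 `O=C1/C(=C\c2ccc(O)c(O)c2)S/C(=N/c2ccccc2)N1Cc1ccncc1` gives 16200 nM

On these numbers compound 3 cannot be separated from the other two: the data show a 1.2-fold lower number from compound 1 to compound 3 (0.08 log units; within the scatter) and a 2.0-fold lower number from compound 2 to compound 3 (0.30 log units; within the scatter) as the two steps reaching it.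

Compound 4 `COc1ccc(/C=C2/S/C(=N/c3ccccc3)N(Cc3ccncc3)C2=O)cc1OC` has not yet been measured. It carries 3,4-dimethoxyphenyl in place of 3,4-dihydroxyphenyl on a double-bonded chain carbon bound to a double-bonded ring carbon, and the rest of the molecule stays the same. Among the compounds with values here, no measured pair makes this exact exchange, so the evidence is indirect. The two steps into compound 3 replaced the group at this same place, and a 1.6-fold higher number from compound 1 to compound 2 (0.21 log units; within the scatter) also alters that group. In all three compounds, then, quite different groups here leave the numbers within the scatter of one another, and none of the three goes against this. No step beyond the scatter is therefore expected in this assay for the new exchange, and the direction is uncertain. The estimated step is a 1.2-fold higher number from compound 3 to compound 4 (0.09 log units; within the scatter) and it is a small one. For compound 4 the expected value is 20000 nM with an estimated range from 10000 nM to 40000 nM when the measurement is made.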

Compound 4, half-maximal inhibitory concentration: 28900 nM
Compound 4: middle estimate off by 1.4-fold (0.16 log units), on the low side; the measured number falls inside the stated range.
By their numbers in this assay, from the lowest: compounds 3, 1, 4 and 2 (each within the scatter of the next).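

In this assay, the 2 hydrogen-bond donors of 3,4-dihydroxyphenyl give way to 0 in 3,4-dimethoxyphenyl, and the result is a 1.8-fold higher number from compound 3 to compound 4 (0.25 log units; within the scatter): at this place, on a double-bonded chain carbon bound to a double-bonded ring carbon, this exchange of hydroxyl for methoxy leaves the number within the scatter. The new group also cannot be told apart from the two alkyl-bearing groups, with a 1.1-fold lower number from compound 2 to compound 4 (0.05 log units; within the scatter) and a 1.5-fold higher number from compound 1 to compound 4 (0.17 log units; within the scatter), so all four compounds now fall within the scatter of one another, with none going against this. No measurement shown offers a reason for this flat picture.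

Going by these compounds, all four groups at this place are substituted phenyl rings, so it remains open whether a ring bearing an amine or a carboxylic acid, or a longer chain in place of the ring, would give a step beyond the scatter. The rest of the molecule is the same throughout, which leaves open whether changes elsewhere on the shared core would move the number at all.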